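A few compounds are considered here, and "the series" means these few. Any claim that something is new, unique, unknown or untested is made for them only; others in the source may bear on it.

Measured so far in an assay on BV-2 cells for positive allosteric modulation of metabotropic glutamate receptor 5 (Mus musculus), read by Griess assay, with stated times of 1 h and 24 h; a higher number here means a weaker inhibitor, a lower number a stronger inhibitor:
compound 1 `O=C(Nc1nc2ccccc2[nH]1)c1cccc(Cl)c1`, 29000 nM
compound 2 `O=C(Nc1nc2ccccc2[nH]1)c1cccc(C(F)(F)F)c1`, 12000 nM

Among the measured compounds shown here, compound 1 stands at the higher of the two numbers; the single step of a 2.4-fold lower number from compound 1 to compound 2 (0.38 log units; beyond the scatter) is the only comparison in hand. Compound 3 `O=C(Nc1nc2ccccc2[nH]1)c1ccc(Cl)c(Cl)c1` differs from compound 1 by chloro in place of hydrogen on an aromatic carbon. For the measured compounds named here, no measured step adds a group to the same ring, so the step from compound 1 to compound 2 bears on it only loosely, as the one case of a change on that ring giving a modest shift. A modest step in this assay is expected, tending lower, with the chance of none beyond the scatter. Compound 3 is estimated at 15000 nM, range 5000 nM to 40000 nM, corresponding to the expected step of a 1.9-fold lower number from compound 1 to compound 3 (0.29 log units; within the scatter).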

Compound 3, half-maximal inhibitory concentration: 9800 nM
Compound 3: the middle estimate sits 1.5-fold (0.18 log units) above what was measured; low and high end bracket the measured number.
By their numbers in this assay, from the lowest: compounds 3 and 2 (each within the scatter of the next); then compound 1.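

In this assay the added chloro, ortho to a chloro group and para to a large group, gives a 3.0-fold lower number from compound 1 to compound 3 (0.47 log units; beyond the scatter) as a modest step. This position therefore takes a substituent in place of hydrogen with a lower number, whereas the earlier comparison covered only an exchange of one group for another. Nothing available accounts for the shift.

The compounds shown leave open whether an amine or a carboxylic acid at this position would shift the number in the same direction. Going by these compounds, whether the added chloro gives a similar step without the first chloro also remains open.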